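This account rests on a few compounds, and the source may have more. Where it says the series, first, only, none or still open, it means among the compounds named here.

Measured in a functional assay with Homo sapiens as the target; a higher number here means a weaker inhibitor, a lower number a stronger inhibitor:
- compound 1 `CC(C)[C@H](NC(=O)COc1cccc2ccccc12)C(=O)N[C@@H](CC(=O)O)C(=O)COc1ccccc1C(F)(F)F`: 17300 nM
- compound 2 `CC(C)[C@H](NC(=O)COc1cccc2ccccc12)C(=O)N[C@@H](CC(=O)O)C(=O)COc1ccc([N+](=O)[O-])cc1`: 22800 nM
- compound 3 `CC(C)[C@H](NC(=O)COc1cccc2ccccc12)C(=O)N[C@@H](CC(=O)O)C(=O)COc1ccccc1F`: 15700 nM

Compound 3 stands level with the other two, with every gap inside the scatter. The next analogue, compound 4 `CC(C)[C@H](NC(=O)COc1cccc2ccccc12)C(=O)N[C@@H](CC(=O)O)C(=O)COc1cccc(F)c1`, carries 3-fluorophenyl in place of 2-fluorophenyl on an oxygen on a saturated carbon. For the measured compounds named here, no measured step changes only the place of the fluoro group. The closest evidence is the exchange of substituted phenyl groups at this same place: a 1.1-fold lower number from compound 1 to compound 3 (0.04 log units; within the scatter), a 1.5-fold lower number from compound 2 to compound 3 (0.16 log units; within the scatter) and a 1.3-fold higher number from compound 1 to compound 2 (0.12 log units; within the scatter). All three lie within the scatter, so no step beyond it is expected in this assay. The expected change is a 1.1-fold higher number from compound 3 to compound 4 (0.03 log units; within the scatter). Compound 4 is estimated at 17000 nM, with an expected range of 9500 nM to 30000 nM.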

Compound 4, half-maximal inhibitory concentration: 12000 nM
For compound 4 the middle estimate is 1.4-fold (0.15 log units) above the measured one; low and high end bracket the measured number.
By their numbers in this assay, from the lowest: compounds 4, 3, 1 and 2 (each within the scatter of the next).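

In this assay, for the compounds shown here, 3-fluorophenyl in place of 2-fluorophenyl gives a 1.3-fold lower number from compound 3 to compound 4 (0.12 log units; within the scatter) and is the first step that changes only the place of the fluoro group. The exchanges for the other two phenyl groups give a 1.9-fold lower number from compound 2 to compound 4 (0.28 log units; within the scatter) and a 1.4-fold lower number from compound 1 to compound 4 (0.16 log units; within the scatter) so all four substituted phenyl groups at this place remain level. No evidence at hand bears on this result.

Open, from the compounds shown here alone, is whether 4-fluorophenyl stays level too. Also open, going by these compounds, is whether an amine or a carboxylic acid on the phenyl ring would give a step beyond the scatter.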